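Trimming a Branched Chain: Expected Clearance of Compound 3

This account rests on a few compounds, and the source may have more. Where it says the series, first, only, none or still open, it means among the compounds named here.

Of the compounds shown here, two sharing the same core have been measured in an ADME assay on cells (Hepatocyte, Homo sapiens) for metabolic stability, read by LC-MS, with a stated time of 60 min, tested at 1 uM; a higher number here means faster removal of the compound, a lower number slower removal. Compound 1 `COc1cc(N(CC2CC2)c2ccc(Cl)c(Cl)c2)cnc1C(=O)[C@H]1C[C@@H]1C(=O)O` gives 4.3 uL/min there. Compound 2 `COc1cc(N(CC(C)C)c2cccc(C(F)(F)F)c2)cnc1C(=O)[C@H]1C[C@@H]1C(=O)O` gives 2.9 uL/min in this assay. These two numbers lie within the usual scatter of repeated measurements of one another, so the data do not separate them.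

Compound 3 `CCN(c1cccc(C(F)(F)F)c1)c1cnc(C(=O)[C@H]2C[C@@H]2C(=O)O)c(OC)c1` has not yet been measured. It differs from compound 2 in a single place: methyl in place of isopropyl on a saturated chain carbon bound to a nitrogen on an aromatic ring. For the measured compounds named here, no measured pair shows this particular change, so the expectation rests only on the two numbers in hand and on how small the change is. The step is expected to be minor, at most a slight lowering, and probably not beyond the scatter; the estimated step is a 1.2-fold lower number from compound 2 to compound 3 (0.06 log units; within the scatter). Compound 3 is therefore expected to give 2.5 uL/min in this assay, with a likely range from 1.2 uL/min to 5 uL/min.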

Compound 3, intrinsic clearance in a liver preparation (reported as CLH), per the amount of preparation that the assay uses: 3.1 uL/min
Compound 3: middle estimate off by 1.2-fold (0.09 log units), on the low side; the measured number falls inside the stated range.
By their numbers in this assay, from the lowest: compounds 2, 3 and 1 (each within the scatter of the next).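

Putting methyl in place of isopropyl on a saturated chain carbon bound to a nitrogen on an aromatic ring gives a 1.1-fold higher number from compound 2 to compound 3 (0.03 log units; within the scatter) in this assay. For the compounds shown here, this is the first measured pair here that differs in one place only, and it shows that the branched isobutyl chain and the shorter ethyl chain cannot be told apart at this position by this read-out. Nothing measured here bears on the reason for that.

Going by these compounds, whether this holds for a longer chain such as hexyl, or for a chain ending in an amine or a hydroxyl group, remains open. On these data alone, it is also open whether the same change would read alike on the aromatic ring that compound 1 carries, with its two chlorines.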